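Dimethylamino in place of hydrogen on the shared core

The compounds below may be only part of what the source reports. "The series", "measured", "known", "first", "only" and "open" are said of these compounds alone.

Measured compounds in a functional assay on aorta (Rattus norvegicus, strain Wistar) for inhibition, with a stated time of 60 min; on this read-out higher numbers stand for an effect only at larger amounts of compound and lower numbers for an effect already at smaller amounts:
compound 1 `CCCOc1ccc(-c2nc3cc(C(F)(F)F)ccc3[nH]2)cc1`: 524000 nM
compound 2 `FC(F)(F)c1ccc2[nH]c(-c3ccccc3)nc2c1`: 468000 nM
compound 3 `CCOc1ccccc1-c1nc2cc(C(F)(F)F)ccc2[nH]1`: 549000 nM

In this assay compound 2 gives a number that is separated from those of compound 1 and compound 3 only within the scatter: the step of a 1.1-fold lower number from compound 1 to compound 2 (0.05 log units; within the scatter) and the step of a 1.2-fold higher number from compound 2 to compound 3 (0.07 log units; within the scatter) are both too small to count as a change. All three compounds share the same core, and neither the propoxy of compound 1 nor the ethoxy of compound 3 moves the read-out beyond the scatter.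

Compound 4 `CN(C)c1ccc(-c2nc3cc(C(F)(F)F)ccc3[nH]2)cc1` differs from compound 2 by dimethylamino in place of hydrogen on an aromatic carbon. The two steps that bear on this change, the removal of propoxy from compound 1 to compound 2 and the addition of ethoxy from compound 2 to compound 3, were both within the scatter, so no step beyond the scatter is expected in this assay for the dimethylamino group either. The estimate for compound 4 is therefore 480000 nM, with a range from 200000 nM to 1200000 nM, which corresponds to an expected step of a 1.0-fold higher number from compound 2 to compound 4 (0.01 log units; within the scatter).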

Compound 4, half-maximal effective concentration: 550000 nM
Beside the measured number, compound 4's estimate is 1.1-fold (0.06 log units) below it, within the range that was stated.
By their numbers in this assay, from the lowest: compounds 2, 1, 3 and 4 (each within the scatter of the next).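

In this assay the place para to a large group now carries dimethylamino, a group joined through nitrogen rather than through oxygen as in propoxy and ethoxy, and even so the read-out shows a 1.2-fold higher number from compound 2 to compound 4 (0.07 log units; within the scatter) and thus no change. The direct exchange of propoxy for dimethylamino at this place gives a 1.0-fold higher number from compound 1 to compound 4 (0.02 log units; within the scatter) and so does not separate the two groups either. No measurement offered here bears on why the read-out stays flat at this place.

Every step shown lies within the scatter, so no group has yet been seen to move the read-out, and whether a carboxylic acid, a primary amine or a longer alkoxy chain would do so remains open. Also open, going by these compounds, is whether this flatness would persist with something other than trifluoromethyl on the shared core.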